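A few compounds are considered here, and "the series" means these few. Any claim that something is new, unique, unknown or untested is made for them only; others in the source may bear on it.

Measured compounds:
compound 1, `COc1ccc(C2C(C#N)=C(N)N(c3cc(OC)c(OC)c(OC)c3)C3=C2C(=O)CC(C)(C)C3)cc1`: 0%
compound 2, `COc1cc(N2C(N)=C(C#N)C(c3ccc(C)cc3)C3=C2CC(C)(C)CC3=O)cc(OC)c1OC`: 30%

In a functional assay on Ehrlich cells (Mus musculus) for cytotoxicity, tested at 10 ug/mL (on this read-out higher numbers stand for a stronger effect at the one concentration tested and lower numbers for a weaker effect), compound 1 stands at the lower of the two numbers shown; its nearest neighbour is compound 2, and the step of a number 30 percentage points higher from compound 1 to compound 2 (beyond the scatter) lies beyond the scatter. Compound 3, `COc1cc(N2C(N)=C(C#N)C(c3ccccc3)C3=C2CC(C)(C)CC3=O)cc(OC)c1OC`, has not yet been tested in this assay. It differs from compound 1 in one place: hydrogen in place of methoxy on an aromatic carbon. The same difference, cut one bond further out, reads 4-methoxyphenyl to phenyl. Going by the values given here, only the step from compound 1 to compound 2 bears on this; there the same methoxy is exchanged for methyl rather than removed. Among the compounds with values here, because a number 30 percentage points higher from compound 1 to compound 2 (beyond the scatter) showed a modest rise on exchanging that methoxy, a rise of similar or smaller size is expected for compound 3, with the uncertainty that no measured pair shows the loss of the group itself. Compound 3 is therefore estimated at 15%, within 0% to 40%, an expected step of a number 15 percentage points higher from compound 1 to compound 3 (beyond the scatter).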

Compound 3, a percentage reported as activity, at one concentration (the size of the read-out at that concentration, not a potency): 0%
For compound 3 the middle estimate is 15 percentage points above the measured one; the range from low to high includes it.
By their numbers in this assay, from the lowest: compounds 1 and 3 (each within the scatter of the next); then compound 2.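

In this assay, replacing the 4-methoxyphenyl with phenyl gives no change at the digits printed from compound 1 to compound 3 (within the scatter) and so separates the loss of the methoxy from the arrival of a new group. Going the other way, removing the methyl gives a number 30 percentage points lower from compound 2 to compound 3 (beyond the scatter) at the same place, para to a large group, so among these three compounds the higher number goes with the methyl itself and not with the absence of methoxy. Nothing available here accounts for why the methyl stands apart from hydrogen and methoxy at this position.

Going by these compounds, with a single compound above the others, it remains open whether the effect is particular to methyl or would extend to a longer chain such as ethyl. Also open, on these data alone, is how a chlorine, an amine or a carboxylic acid at this position would read.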